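Cyano to trifluoromethoxy on a thiophene-linked biaryl series

The source may hold more compounds than are shown below. What is called first, only, known or untested is meant among the compounds shown, and "the series" means these compounds.

Compound 1, `N#Cc1ccc(-c2cccc(CO[C@@H]3COc4nc([N+](=O)[O-])cn4C3)c2)cc1`, gives in an ADME assay on Vero cells (Chlorocebus sabaeus) for cytotoxicity, with a stated time of 72 h (a lower number here means a stronger inhibitor, a higher number a weaker inhibitor), a value of > 128000 nM, which is a limit of the assay.
Compound 2, `O=[N+]([O-])c1cn2c(n1)OC[C@@H](OCc1cccc(-c3ccc(OC(F)(F)F)cc3)c1)C2`, gives in this assay a value of > 128000 nM, which is a limit of the assay.
Compound 3, `N#Cc1ccc(-c2ccc(CO[C@@H]3COc4nc([N+](=O)[O-])cn4C3)s2)cc1`, gives in this assay a value of > 128000 nM, which is a limit of the assay.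

Compound 3 therefore stands where every measured member of this small set stands: at the limit of > 128000 nM in this assay, at which 3 of the 3 values shown sit. No number separates it from compound 1 or compound 2, and no order among the three can be read.

The move to compound 4, `O=[N+]([O-])c1cn2c(n1)OC[C@@H](OCc1ccc(-c3ccc(OC(F)(F)F)cc3)s1)C2`, is a single change: trifluoromethoxy in place of cyano on an aromatic carbon. Going by the values given here, the one measured step that makes the same exchange, a step that the two limits leave unreadable from compound 1 to compound 2, runs between two limits and leaves no readable size. The evidence thus gives no direction for the step from compound 3 to compound 4, and it gives no reason to expect a number inside the measured window.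

The expectation for compound 4 in this assay is therefore a value at or beyond the limit, with the step that the limit leaves unreadable from compound 3 to compound 4 expected to be unreadable in the same way. Compound 4 is estimated at 200000 nM, with a range from 100000 nM to 500000 nM.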

Compound 4, half-maximal inhibitory concentration: > 128000 nM
Compound 4: only a limit was reported (the forecaster's own chance of this, stated with the estimate: 85%); the middle value lies beyond the limit too.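

In this assay compound 4 gives > 128000 nM, which is a limit of the assay, so no step from compound 3 to compound 4 can be read, and the set stands at one value: the limit of > 128000 nM in this assay, at which 4 of the 4 values shown sit.

The compounds shown leave open how the four differ in this read-out, and whether trifluoromethoxy in place of cyano changes it at all.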